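A Longer Chain on an Inactive Core

This account rests on a few compounds, and the source may have more. Where it says the series, first, only, none or still open, it means among the compounds named here.

Compound 1 `CC(C)(C)OC(=O)NCCC[C@@H]1N=C2C[C@@H]3C[C@@H](C3(C)C)[C@]2(C)OC1=O` was examined in an ADME assay on NIH3T3 cells (Mus musculus) for antiproliferative activity, read by sulforhodamine B assay, with a stated time of 48 h; a lower number here means a stronger inhibitor, a higher number a weaker inhibitor. In this assay compound 1 gives only > 1200000 nM, which is a limit of the measurement and not a number. Its mirror image, compound 3 `CC(C)(C)OC(=O)NCCC[C@H]1N=C2C[C@H]3C[C@H](C3(C)C)[C@@]2(C)OC1=O`, likewise gives only a limit in this assay, > 1500000 nM. Compound 2 `CC1(C)[C@@H]2CC3=N[C@@H](CCC(=O)O)C(=O)O[C@@]3(C)[C@H]1C2`, which carries a different side chain on the shared core, also gives a limit in this assay, > 1200000 nM. The step that the two limits leave unreadable from compound 1 to compound 3 therefore cannot be read in size; the two values sit at the limits the limit of > 1200000 nM in this assay, at which 2 of the 3 values shown sit, and (the limit of > 1500000 nM in this assay, at which 1 of the 3 values shown sits), and the pair differs only in configuration (the fact that compounds 1 and 3 differ only in the configuration as drawn).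

Compound 4 `CC(C)(C)OC(=O)NCCCC[C@@H]1N=C2C[C@@H]3C[C@@H](C3(C)C)[C@]2(C)OC1=O` differs from compound 1 by one change: ((tert-butoxycarbonyl)amino)methyl in place of (tert-butoxycarbonyl)amino on a saturated chain carbon, three bonds along the chain from a saturated ring carbon. For the measured compounds named here, no measured step bears on lengthening this chain, and every value shown is a limit, so there is no readable step to build on. Compound 4 is expected to stay at the limit, a step of a number no higher from compound 1 to compound 4 (the limit leaves the size open) that is not beyond the scatter. The estimate for compound 4 is 1200000 nM, within a range from 600000 nM to 3000000 nM.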

Compound 4, half-maximal inhibitory concentration: > 800000 nM
Compound 4: only a limit was reported; the forecaster's own chance of this, stated with the estimate: 85%; the middle value is on the limit's open side.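

For the compounds shown here, compound 1 and compound 4 both give only limits of the measurement in this assay, not numbers, so no step between them can be read. The compounds shown leave open whether the longer chain, or any other side chain on the shared core, changes activity in this assay.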